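A Fluorinated Chlorophenyl Ring on a Weakly Active Core

The source may hold more compounds than are shown below. What is called first, only, known or untested is meant among the compounds shown, and "the series" means these compounds.

Compound 1 `COc1cc(C)ccc1S(=O)(=O)NC1=NCCN1C(=S)SN1CCn2c1nsc2=S` was tested in a functional assay on KYSE-510 cells (Homo sapiens) for antiproliferative activity, read by crystal violet staining, with a stated time of 96 h; a higher number here means a weaker inhibitor of growth, a lower number a stronger inhibitor of growth. In this assay compound 1 gives >= 20000 nM, which is a limit of the assay rather than a number. Compound 2 `O=S(=O)(NC1=NCCN1C(=S)SN1CCn2c1nsc2=S)c1ccc(Cl)c(Cl)c1Cl` carries a different ring on the sulfonyl sulfur. In this assay compound 2 gives >= 20000 nM, likewise a limit. The step that the two limits leave unreadable from compound 1 to compound 2 therefore cannot be read. Both values sit together at the same limit (the limit of >= 20000 nM in this assay, at which 2 of the 2 values shown sit). Compound 3 `O=S(=O)(NC1=NCCN1C(=S)SN1CCn2c1nsc2=S)c1ccc(F)c(Cl)c1` has not yet been measured. It differs from compound 1 in one place: 3-chloro-4-fluorophenyl in place of 2-methoxy-4-methylphenyl on a sulfonyl sulfur. Among the compounds with values here, the only comparable exchange of the ring on the sulfonyl sulfur, a step that the two limits leave unreadable from compound 1 to compound 2, left the value at the limit (the limit of >= 20000 nM in this assay, at which 2 of the 2 values shown sit), so no step beyond the scatter is expected in this assay. Compound 3 is expected to give 20000 nM, between 8000 nM and 50000 nM, most likely reported again only as a limit. The expected step of a number no higher from compound 1 to compound 3 (the limit leaves the size open) is accordingly none beyond the scatter.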

Compound 3, concentration for 50% growth inhibition: >= 20000 nM
Compound 3 was reported as a limit; the forecaster's own chance of this, stated with the estimate: 85%; the middle value sits exactly at the limit.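

Compound 3, like compound 1 and compound 2, gives only a limit of the assay and not a number, so no step among the three can be read: the limit of >= 20000 nM in this assay, at which 3 of the 3 values shown sit.

The compounds shown leave open whether any ring on the sulfonyl sulfur gives the shared core a measurable value in this assay.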